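Swapping fluoro for tert-butyl on a thioether-linked aryl ring

The source may hold more compounds than are shown below. What is called first, only, known or untested is meant among the compounds shown, and "the series" means these compounds.

Measured so far:
Compound 1 `COc1ccc(SCc2ccc(/C=C/C(=O)Nc3ccccc3N)cc2)cc1OC`: 80.6%
Compound 2 `Nc1ccccc1NC(=O)/C=C/c1ccc(CSc2ccc(F)cc2)cc1`: 59.1%
Compound 3 `Cc1ccc(SCc2ccc(C(=O)Nc3ccccc3N)cc2)cc1`: 78.3%

In a functional assay on A549 cells (Homo sapiens) for inhibition, read by CCK-8 assay, with a stated time of 72 h, tested at 8 uM (a lower number here means less inhibition of growth, a higher number more inhibition of growth at the concentration tested), compound 2 gives 59.1%, the lowest of the three numbers; both compound 1 and compound 3 sit beyond the scatter above it. For the measured compounds named here, the one measured step that changes only the ring on the sulfur is a number 21.5 percentage points lower from compound 1 to compound 2 (beyond the scatter), a modest loss when 4-fluorophenyl replaces 3,4-dimethoxyphenyl. Going by the values given here, compound 3 differs from compound 2 in more than one place, so its value shows only that a methyl-bearing ring on the sulfur is compatible with a high number.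

Compound 4 `CC(C)(C)c1ccc(SCc2ccc(/C=C/C(=O)Nc3ccccc3N)cc2)cc1` is not yet measured. It differs from compound 2 by tert-butyl in place of fluoro on an aromatic carbon. Among the compounds with values here, no measured step covers this exact change. Within the data shown here, the only step on this ring says that fluoro is the weaker choice among those tried, so a gain beyond the scatter is expected, though its size is uncertain. Compound 4 is estimated at 71%, within 52% to 88%, a step of a number 11.9 percentage points higher from compound 2 to compound 4 (beyond the scatter) expected from compound 2.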

Compound 4, percent growth inhibition at one concentration: 79.8%
Compound 4: the middle estimate sits 8.8 percentage points below what was measured; measured number inside the range.
By their numbers in this assay, from the lowest: compound 2; then compounds 3, 4 and 1 (each within the scatter of the next).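

In this assay, the step of a number 20.7 percentage points higher from compound 2 to compound 4 (beyond the scatter) shows that this position on the ring attached to sulfur accepts tert-butyl, with four heavy atoms, in place of fluoro, with one, and that the larger group goes with more growth inhibition at the concentration tested. The step of a number 0.8 percentage points lower from compound 1 to compound 4 (within the scatter) adds that 4-(tert-butyl)phenyl and 3,4-dimethoxyphenyl cannot be told apart here, so among compounds 1, 2 and 4 only the 4-fluorophenyl compound stands lower. Nothing measured here gives a reason for that difference.

Still open, as far as these compounds go, is how a charged group such as an amine or a carboxylic acid at this position would compare. A bare phenyl ring or a longer alkyl chain would show whether the number follows the size of the group or is specific to fluoro.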